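A fluoro step from compound 2 to compound 3

The source may report more compounds than this note shows. Statements on the series, on what has been measured and on what is new or still open speak of the compounds shown alone.

compound 1 `O=C(CN1CCN(C(=O)c2ccc(F)cc2)CC1)N1CCN(CCCc2c[nH]c3ccccc23)CC1` gives 188000 nM
compound 2 `COc1cccc(C(=O)N2CCN(CC(=O)N3CCN(CCCc4c[nH]c5ccccc45)CC3)CC2)c1` gives > 200000 nM (a limit)

In an ADME assay on SH-SY5Y cells (Homo sapiens) for cytotoxicity, read by MTT assay, with a stated time of 72 h (a higher number here means a weaker inhibitor, a lower number a stronger inhibitor), compound 2 sits at a limit of the assay (> 200000 nM) and has no exact number. Compound 3 `COc1cccc(C(=O)N2CCN(CC(=O)N3CCN(CCCc4c[nH]c5ccc(F)cc45)CC3)CC2)c1` differs from it by fluoro in place of hydrogen on an aromatic carbon (1H-indol-3-yl to 5-fluoro-1H-indol-3-yl). Going by the values given here, the only measured step (an at least 1.0-fold higher number from compound 1 to compound 2 (0.02 log units; that floor lies within the scatter)) concerns a different group, so no measured step bears directly on this change. No step beyond the scatter is therefore expected in this assay. The expected step is small (a number no higher from compound 2 to compound 3 (the limit leaves the size open)). Compound 3 is estimated at 200000 nM (expected range 100000 nM to 400000 nM).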

Compound 3, half-maximal inhibitory concentration: 79400 nM
Compound 3: the middle estimate sits 2.5-fold (0.40 log units) above what was measured, outside the stated range (below it).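

In this assay, fluoro in place of hydrogen on the 1H-indol-3-yl group gives an at least 2.5-fold lower number from compound 2 to compound 3 (0.40 log units; beyond the scatter). This shows that the number responds to a change at this position, which the earlier step, on a different group, did not show. The full size of the step stays unknown because compound 2 has only a limit: the limit of > 200000 nM in this assay, at which 1 of the 3 values shown sits.

The compounds shown leave open whether chloro, methoxy or an amine at this place would move the number in the same direction. They also leave open whether fluoro here would do the same alongside the 4-fluorophenyl group of compound 1.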